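Moving a Bromine Around a Benzyl Ring

The source may report more compounds than this note shows. Statements on the series, on what has been measured and on what is new or still open speak of the compounds shown alone.

Measured so far:
compound 1, `O=C(/C=C/c1ccc(OCc2cn(Cc3cccc(Br)c3)nn2)cc1)c1ccc(Br)cc1`, gives 25% in a functional assay on HepG2 cells (Homo sapiens) for inhibition, read by MTT assay, with a stated time of 48 h, tested at 10 uM; a higher number here means more inhibition of growth at the concentration tested, a lower number less inhibition of growth.
compound 2, `O=C(/C=C/c1ccc(OCc2cn(Cc3ccc(Br)cc3)nn2)cc1)c1ccc(Br)cc1`, gives 22% in this assay.
compound 3, `COc1ccc(C(=O)/C=C/c2ccc(OCc3cn(Cc4cccc(Br)c4)nn3)cc2)cc1`, gives 27% in this assay.

All three compounds share one core and differ only at two points. Compound 3 differs from compound 1 by methoxy in place of bromo on an aromatic carbon, and in this assay this gives a number 2 percentage points higher from compound 1 to compound 3 (within the scatter). Compound 2 differs from compound 1 by 4-bromophenyl in place of 3-bromophenyl on a saturated chain carbon bound to an aromatic nitrogen, and this gives a number 3 percentage points lower from compound 1 to compound 2 (within the scatter). The three values therefore sit close together, none of them separated from another by more than the usual scatter, so no ordering among them can be claimed.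

Compound 4, `COc1ccc(C(=O)/C=C/c2ccc(OCc3cn(Cc4ccc(Br)cc4)nn3)cc2)cc1`, has not yet been measured. It differs from compound 3 by 4-bromophenyl in place of 3-bromophenyl on a saturated chain carbon bound to an aromatic nitrogen. The place of this change is worded exactly as for the change from compound 1 to compound 2, so it is the same change, now made on the core that carries methoxy instead of bromo.

Because the same change gave a number 3 percentage points lower from compound 1 to compound 2 (within the scatter), compound 4 is expected to show a step of a number 3 percentage points lower from compound 3 to compound 4 (within the scatter) in this assay, a step as small as the earlier one. Compound 4 is therefore estimated at 24%. Compound 4 should most likely fall between 14% and 34%.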

Compound 4, percent growth inhibition at one concentration: 59%
The estimate for compound 4 lay 35 percentage points below the measured number, outside the stated range (above it).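

On the core that carries methoxy, 4-bromophenyl in place of 3-bromophenyl on a saturated chain carbon bound to an aromatic nitrogen gives a number 32 percentage points higher from compound 3 to compound 4 (beyond the scatter) in this assay, so the effect seen on the core that carries bromo does not carry over: the same change on two cores in this assay, a number 3 percentage points lower (within the scatter) from compound 1 to compound 2 and a number 32 percentage points higher (beyond the scatter) from compound 3 to compound 4, 35 percentage points apart, beyond the scatter of two such steps

Read the other way, methoxy in place of bromo on an aromatic carbon gives a number 37 percentage points higher from compound 2 to compound 4 (beyond the scatter), so the effect of this second change also depends on which bromophenyl group is present: the same change on two cores in this assay, a number 2 percentage points higher (within the scatter) from compound 1 to compound 3 and a number 37 percentage points higher (beyond the scatter) from compound 2 to compound 4, 35 percentage points apart, beyond the scatter of two such steps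

Together, these results show that the two changes do not simply add up across these four compounds, but they do not show why, and both comparisons rest on the single value of compound 4.

The compounds shown leave open whether the higher number in compound 4 depends on methoxy itself or would also appear with ethoxy, an amine or a carboxylic acid in its place. They also leave open whether the 4-bromophenyl group is needed as such, or whether a 4-chlorophenyl group would show the same dependence on the other end of the molecule.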